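The source may report more compounds than this note shows. Statements on the series, on what has been measured and on what is new or still open speak of the compounds shown alone.

Measured compounds in an assay on NIH3T3 cells for binding affinity to melatonin receptor type 1A (Homo sapiens); a higher number here means a weaker inhibitor, a lower number a stronger inhibitor:
- compound 1 `COc1cccc2[nH]c(CNC(C)=O)cc12`, compound 1 gives 1230 nM
- compound 2 `CCC(=O)NCc1cc2c(OC)cccc2[nH]1`, compound 2 gives 407 nM
- compound 3 `COc1cccc2[nH]c(CNC(=O)C3CCC3)cc12`, compound 3 gives 525 nM

Compound 2 holds the lowest of the three numbers in this assay. Its gap to compound 3 is small, a 1.3-fold higher number from compound 2 to compound 3 (0.11 log units; within the scatter), so the two are not separated; its gap to compound 1 is clear, a 3.0-fold lower number from compound 1 to compound 2 (0.48 log units; beyond the scatter). The other step on record, a 2.3-fold lower number from compound 1 to compound 3 (0.37 log units; beyond the scatter), also lies at the carbonyl carbon.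

Compound 4 `CCC(=O)NCc1cc2c(OC)cccc2n1Cc1ccccc1` keeps the propanoyl amide of compound 2 and changes a different place: benzyl in place of hydrogen on an aromatic nitrogen. Going by the values given here, no measured step touches the aromatic nitrogen; all three steps concern the group on the carbonyl carbon, so none of them bears directly on this change. The data give no anchor for the size or direction of the step, and the expectation rests only on the scale of the steps seen so far, which were modest throughout.

For compound 4 a modest weakening is expected, a 2.9-fold higher number from compound 2 to compound 4 (0.47 log units; beyond the scatter), with a wide range. The estimate for compound 4 in this assay is 1200 nM, between 300 nM and 5000 nM.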

Compound 4, inhibition constant: 631 nM
Compound 4: middle estimate off by 1.9-fold (0.28 log units), on the high side; the range from low to high includes it.
By their numbers in this assay, from the lowest: compounds 2, 3, 4 and 1 (each within the scatter of the next, the first and the last beyond it).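

In this assay, benzyl in place of hydrogen on the aromatic nitrogen gives a 1.6-fold higher number from compound 2 to compound 4 (0.19 log units; within the scatter), so the two compounds are not separated, even though the change adds 7 heavy atoms and one six-membered aromatic ring. Going by these compounds alone, this is the first reading at this position, as every earlier step concerned the group on the carbonyl carbon, and it shows that for this pair the hydrogen on the aromatic nitrogen can be replaced by benzyl without a change beyond the scatter. No supporting measurement is available to explain why this substitution is tolerated.

Going by these compounds, the benzyl result rests on the propanoyl amide alone, so it remains open whether the same substitution would behave alike with the amide of compound 1 or that of compound 3. Also open, on these data alone, is how the aromatic nitrogen would respond to a methyl group, a longer chain such as phenethyl, or a benzyl group carrying an amine or a carboxylic acid.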